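The source may hold more compounds than are shown below. What is called first, only, known or untested is meant among the compounds shown, and "the series" means these compounds.

In a functional assay on SGC-7901 cells (Homo sapiens) for antiproliferative activity, read by sulforhodamine B assay, with a stated time of 72 h (a lower number here means a stronger inhibitor, a higher number a weaker inhibitor), compound 1 `COc1ccccc1NC(=S)N/N=C/c1ccc2ccccc2n1` is reported as > 100000 nM, which is a limit of the assay and not a number. Compound 2 `N#Cc1ccc(NC(=S)N/N=C/c2ccc3ccccc3n2)cc1` gives 23700 nM. Compound 3 `S=C(N/N=C/c1ccc2ccccc2n1)Nc1ccc(Br)cc1` gives 69400 nM, the higher of the two values that are actual numbers, which places it on the weaker side of that pair.

Compound 4 `FC(F)(F)c1ccc(NC(=S)N/N=C/c2ccc3ccccc3n2)cc1` has not yet been measured. It differs from compound 3 by trifluoromethyl in place of bromo on an aromatic carbon, with trifluoromethyl in place of bromo on an aromatic carbon.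

Among the measured compounds shown here, the most relevant evidence is the only measured change at this same place, a 2.9-fold higher number from compound 2 to compound 3 (0.47 log units; beyond the scatter). That step is modest, and the replacement in compound 4 is therefore expected to produce a step of about that size or smaller, leaning towards a lower number. The other two steps, an at least 4.2-fold lower number from compound 1 to compound 2 (0.62 log units; beyond the scatter) and an at least 1.4-fold lower number from compound 1 to compound 3 (0.15 log units; that floor lies within the scatter), start from a limit and replace the whole substituted ring group, so they give only floors and say little about this swap.

The estimated change is a 1.5-fold lower number from compound 3 to compound 4 (0.19 log units; within the scatter). For compound 4, the expected value is 45000 nM, with an estimated range from 18000 nM to 100000 nM.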

Compound 4, half-maximal inhibitory concentration: 72200 nM
The estimate for compound 4 lay 1.6-fold (0.21 log units) below the measured number; the range from low to high includes it.
By their numbers in this assay, from the lowest: compound 2; then compounds 3 and 4 (each within the scatter of the next). At a limit, above all of these: compound 1.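

In this assay, trifluoromethyl in place of bromo on this aromatic carbon, para to a large group, gives a 1.0-fold higher number from compound 3 to compound 4 (0.02 log units; within the scatter) and so leaves the reading unchanged within the scatter, although the entering group has 4 heavy atoms and the leaving group 1. Among the compounds shown here, the earlier compounds offered only one measured change at this place, whereas a second comparison with cyano now gives a 3.0-fold higher number from compound 2 to compound 4 (0.48 log units; beyond the scatter) and stands close in size to a 2.9-fold higher number from compound 2 to compound 3 (0.47 log units; beyond the scatter) as the earlier step. Among the three groups compared at this place, the cyano group of compound 2 is thus the only one that separates from the others beyond the scatter, while compound 3 and compound 4 cannot be told apart.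

The compounds shown leave open how an amine or a carboxylic acid on this same carbon would read, and whether the separation of cyano would hold for other groups. Compound 1 provides no number for comparison, only a limit of the assay: the limit of > 100000 nM in this assay, at which 1 of the 4 values shown sits.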